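This account rests on a few compounds, and the source may have more. Where it says the series, first, only, none or still open, it means among the compounds named here.

Compound 1 `COc1ccc(C(c2ccc(O)cc2)c2cccc3ccccc23)c(OC)c1OC`: 16000 nM
Compound 2 `COc1ccc(C(OCc2ccc(C)cc2)c2cccc3ccccc23)c(OC)c1OC`: > 20000 nM

Both values come from a functional assay on HCT-116 cells (Homo sapiens) for inhibition, read by sulforhodamine B assay, with a stated time of 48 h; on this read-out lower numbers stand for stronger inhibition and higher numbers for weaker inhibition. Compound 2 stands at the limit of > 20000 nM in this assay, at which 1 of the 2 values shown sits, so its value is a limit of the assay and not a number. Compound 3 `COc1ccc(C(c2ccc(OCC(=O)O)cc2)c2cccc3ccccc23)c(OC)c1OC` differs from compound 2 by 4-(carboxymethoxy)phenyl in place of (4-methylbenzyl)oxy on a saturated chain carbon bound to two aromatic carbons. For the measured compounds named here, the only measured step, an at least 1.2-fold higher number from compound 1 to compound 2 (0.09 log units; that floor lies within the scatter), went in the reverse direction, swapping an aryl group for the benzyloxy group; the new group in compound 3 again places a phenyl on the saturated chain carbon, now carrying a carboxymethoxy chain. The step of an at least 1.1-fold lower number from compound 2 to compound 3 (0.04 log units; that floor lies within the scatter) is therefore expected to move, if at all, back toward the region of compound 1. Compound 3 is expected to give 18000 nM, within 7000 nM to 40000 nM.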

Compound 3, half-maximal inhibitory concentration: 5020 nM
Estimate against measurement, compound 3: 3.6-fold (0.55 log units) above; measured number below the stated range.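

Carboxymethyl in place of hydrogen on an oxygen on an aromatic ring gives a 3.2-fold lower number from compound 1 to compound 3 (0.50 log units; beyond the scatter) in this assay, so this oxygen can carry a substituent and the number still improves. 4-(Carboxymethoxy)phenyl in place of (4-methylbenzyl)oxy on the saturated chain carbon gives an at least 3.9-fold lower number from compound 2 to compound 3 (0.60 log units; beyond the scatter), and unlike the earlier step, this one clears the scatter. The value of compound 2 is a limit and not a number, so this step is only a floor: the limit of > 20000 nM in this assay, at which 1 of the 3 values shown sits.

As far as these compounds go, whether the gain depends on the carboxylic acid end of the new chain stays open. A methyl ester, a primary amide or a longer chain on that oxygen would address this.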